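The source may hold more compounds than are shown below. What is called first, only, known or untested is meant among the compounds shown, and "the series" means these compounds.

Measured so far:
Compound 1, `COC1=C(OC)[C@H](O)[C@H](C/C=C(\C)CC/C=C(\C)CCC=C(C)C)[C@@H](C)C1=O`: 13500 nM
Compound 2, `COC1=C(OC)[C@H](O)[C@H](C/C=C(\C)CC/C=C(\C)CC/C=C(\C)CO)[C@@H](C)C1=O`: a limit of the assay, > 30000 nM
Compound 3, `COC1=C(OC)[C@H](O)[C@H](C/C=C(\C)CC/C=C(\C)C[C@H](O)C=C(C)C)[C@@H](C)C1=O`: a limit of the assay, > 30000 nM

The three compounds share one core and differ only in the side chain. In a functional assay on PC-3 cells (Homo sapiens) for inhibition, read by sulforhodamine B assay, with a stated time of 48 h (a higher number here means a weaker inhibitor of growth, a lower number a stronger inhibitor of growth), compound 1 gives 13500 nM. Compound 2 does not give a number but only a limit of the assay, > 30000 nM. Compound 3 also gives only a limit of the assay, > 30000 nM. Compound 3 therefore stands at the limit of > 30000 nM in this assay, at which 2 of the 3 values shown sit, and where it truly lies beyond that cannot be read from the numbers shown.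

Compound 4, `COC1=C(OC)[C@H](O)[C@H](C/C=C(\C)CC/C=C(\C)CCCC(C)CO)[C@@H](C)C1=O`, has not yet been measured. It differs from compound 3 in one place: 3-(hydroxymethyl)butyl in place of 1-hydroxy-3-methylbut-2-en-1-yl on a saturated chain carbon bound to a double-bonded chain carbon. For the measured compounds named here, two measured steps bear on this change, both adding a hydroxy to the chain: an at least 2.2-fold higher number from compound 1 to compound 2 (0.34 log units; beyond the scatter) and an at least 2.2-fold higher number from compound 1 to compound 3 (0.34 log units; beyond the scatter). The third step, a step that the two limits leave unreadable from compound 2 to compound 3, cannot be sized. Compound 4 keeps a hydroxy on the chain, as compounds 2 and 3 do, so the expected step of a number no higher from compound 3 to compound 4 (the limit leaves the size open) is no movement beyond the scatter, most likely again a limit. Compound 4 is thus estimated at 30000 nM, in a range from 12000 nM to 60000 nM.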

Compound 4, concentration for 50% growth inhibition: > 30000 nM
Compound 4 was reported as a limit; the forecaster's own chance of this, stated with the estimate: 60%; the middle value lies on the limit itself.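

In this assay, for the compounds shown here, there is an at least 2.2-fold higher number from compound 1 to compound 4 (0.34 log units; beyond the scatter), and this is the first such step with a hydroxy on a chain end that has lost its double bond. The 3-(hydroxymethyl)butyl end of compound 4 is saturated, yet the weaker growth inhibition seen with the hydroxy-bearing, unsaturated chains of compound 2 and compound 3 remains, so among the compounds shown, keeping that double bond is not needed for the drop from compound 1. The steps from compound 2 to compound 4 and from compound 3 to compound 4 cannot be read, and all three hydroxy-bearing compounds share one limit of the assay: the limit of > 30000 nM in this assay, at which 3 of the 4 values shown sit.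

Going by these compounds, how far these three compounds truly lie beyond that limit remains open, so any ranking among them is too. Also open, on these data alone, is how the chain would behave with a plain 3-methylbutyl end carrying no hydroxy, which would separate saturation from the hydroxy directly, or with an amine or a carboxylic acid in the hydroxy's place.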